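Fluorophenylpiperazine succinimide amides: moving the fluorine

The source may report more compounds than this note shows. Statements on the series, on what has been measured and on what is new or still open speak of the compounds shown alone.

Measured so far in a functional assay on the whole organism (strain Swiss) with Mus musculus as the target, in the maximal electroshock model, with a stated time of 2 h, at a dose of 300 mg/kg by the intraperitoneal route; on this read-out higher numbers stand for a stronger effect at the one dose given and lower numbers for a weaker effect:
compound 1 `CC(C(=O)N1CCN(c2ccccc2F)CC1)N1C(=O)CCC1=O` gives 25%
compound 2 `CCC(C(=O)N1CCN(c2ccc(F)cc2)CC1)N1C(=O)CCC1=O` gives 0%
compound 3 `CC(C(=O)N1CCN(c2ccc(F)cc2)CC1)N1C(=O)CCC1=O` gives 50%

The cores of compound 2 and compound 3 differ by methyl in place of hydrogen on a saturated chain carbon, two bonds along the chain from an amide-type nitrogen in a ring and a carbonyl carbon; across that difference the read-out shows a number 50 percentage points higher from compound 2 to compound 3 (beyond the scatter). Within the core of compound 3, the change 2-fluorophenyl in place of 4-fluorophenyl on an amine nitrogen in a ring gives a number 25 percentage points lower from compound 3 to compound 1 (beyond the scatter).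

Compound 4 `CCC(C(=O)N1CCN(c2ccccc2F)CC1)N1C(=O)CCC1=O` is not yet measured. It stands to compound 2 as compound 1 stands to compound 3: the difference is 2-fluorophenyl in place of 4-fluorophenyl on an amine nitrogen in a ring, the same change at the same place. In the core of compound 3 this change lowered the number. Compound 2 already gives the lowest number among the three, so there is little room for a further drop. In this assay, for the measured compounds named here, the step from compound 2 to compound 4 is therefore expected to be a number 5 percentage points higher from compound 2 to compound 4 (within the scatter), because the single known instance is a number 25 percentage points lower from compound 3 to compound 1 (beyond the scatter). Compound 4 is expected to give 5%, within 0% to 20%.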

Compound 4, a percentage reported as activity, at one dose (the size of the read-out at that dose, not a potency): 0%
Estimate against measurement, compound 4: 5 percentage points above; the range from low to high includes it.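

In this assay the fluorine change gives no change at the digits printed from compound 2 to compound 4 (within the scatter), so its size does not carry from one core to the other: the same change on two cores in this assay, a number 25 percentage points lower (beyond the scatter) from compound 3 to compound 1 and no change at the digits printed (within the scatter) from compound 2 to compound 4, 25 percentage points apart, beyond the scatter of two such steps

The added methyl gives a number 25 percentage points lower from compound 1 to compound 4 (beyond the scatter), the same direction as the earlier methyl step but a different size: the same change on two cores in this assay, a number 50 percentage points higher (beyond the scatter) from compound 2 to compound 3 and a number 25 percentage points higher (beyond the scatter) from compound 4 to compound 1, 25 percentage points apart, beyond the scatter of two such steps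

Compound 2 and compound 4 share one value, with compound 4 at 0%, so this pair cannot show whether the fluorine change would lower a number on this core if the number had room to fall.

Open, going by these compounds, is how the read-out responds with an unsubstituted phenyl or a chlorophenyl on the ring nitrogen. Also open, on these data alone, is whether a longer chain in place of the methyl goes further in the same direction.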